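Swapping Nitro for Pyrrolidinylsulfonyl on the Anilide

The source may hold more compounds than are shown below. What is called first, only, known or untested is meant among the compounds shown, and "the series" means these compounds.

compound 1: `O=C(Nc1cccc([N+](=O)[O-])c1)C1CCCN(C(=O)c2cc(C(F)(F)F)cc(C(F)(F)F)c2)C1`, 9%
compound 2: `O=C(Nc1ccc(Cl)cc1)C1CCCN(C(=O)c2cc(C(F)(F)F)cc(C(F)(F)F)c2)C1`, 14%
compound 3: `O=C(Nc1ccc(Cl)nc1)C1CCCN(C(=O)c2cc(C(F)(F)F)cc(C(F)(F)F)c2)C1`, 25%

In an ADME assay on PC-3 cells (Homo sapiens) for cytotoxicity, read by WST assay, tested at 100 uM (a higher number here means more inhibition at the concentration tested (going by the name of the read-out), a lower number less inhibition), compound 1 stands at the low end of the three numbers shown; compound 2 lies within the scatter of it, while compound 3 lies beyond it, as the steps of a number 5 percentage points higher from compound 1 to compound 2 (within the scatter) and a number 16 percentage points higher from compound 1 to compound 3 (beyond the scatter) tell. The related step of a number 11 percentage points higher from compound 2 to compound 3 (beyond the scatter) is also modest. Compound 4 is `O=C(Nc1cccc(S(=O)(=O)N2CCCC2)c1)C1CCCN(C(=O)c2cc(C(F)(F)F)cc(C(F)(F)F)c2)C1`; the change is (pyrrolidin-1-yl)sulfonyl in place of nitro on an aromatic carbon. Going by the values given here, none of the measured steps exchanges one group on the ring for another; each exchanges the whole ring, and all stayed small. Compound 4 is therefore expected to move little, a step of a number 6 percentage points higher from compound 1 to compound 4 (within the scatter) at most modest. Compound 4 is estimated at 15%, between 0% and 35%.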

Compound 4, a percentage reported as inhibition, at one concentration (the size of the read-out at that concentration, not a potency): 0%
Beside the measured number, compound 4's estimate is 15 percentage points above it; measured number inside the range.
By their numbers in this assay, from the lowest: compounds 4, 1 and 2 (each within the scatter of the next, the first and the last beyond it); then compound 3.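

The exchange of one group on the ring, rather than the whole ring, gives in this assay a number 9 percentage points lower from compound 1 to compound 4 (within the scatter) and so leaves the number within the scatter. At this aromatic carbon, meta to a large group, the number thus stays level with (pyrrolidin-1-yl)sulfonyl, with its 8 heavy atoms and five-membered non-aromatic ring, in place of nitro with 3 heavy atoms. Nothing measured here accounts for this result. Going by these compounds, whether an amine or a carboxylic acid at this carbon would also stay within the scatter of compound 1 remains open. So does whether (pyrrolidin-1-yl)sulfonyl would behave alike on the ring of compound 3.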